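Phenyl for Amino on a Triazole Nitrogen

This account rests on a few compounds, and the source may have more. Where it says the series, first, only, none or still open, it means among the compounds named here.

Compound 1 `Cc1cc(C)n2nc(SCc3nnc(SCc4coc5ccccc5c4=O)n3-c3ccccc3)nc2n1`: 22100 nM
Compound 2 `Cc1cc(C)n2nc(SCc3nnc(SCc4cc(=O)c5ccccc5o4)n3N)nc2n1`: > 25000 nM

Of the compounds shown here, two have been measured in a functional assay on HEp-2 cells (Homo sapiens) for cytotoxicity, read by MTT assay, with a stated time of 72 h; a higher number here means a weaker inhibitor, a lower number a stronger inhibitor. Compound 1 gives 22100 nM. For compound 2 this assay reports only a limit, > 25000 nM, which is the limit of > 25000 nM in this assay, at which 1 of the 2 values shown sits. Compound 2 thus sits at the weak end of what is shown. Compound 3 `Cc1cc(C)n2nc(SCc3nnc(SCc4cc(=O)c5ccccc5o4)n3-c3ccccc3)nc2n1` differs from compound 2 by phenyl in place of amino on an aromatic nitrogen. For the measured compounds named here, no measured pair isolates this change, so the step of an at least 1.2-fold lower number from compound 2 to compound 3 (0.09 log units; that floor lies within the scatter) is expected to be small, toward stronger inhibition at most, or none beyond the scatter. Compound 3 is expected to give about 20000 nM, between 9000 nM and 40000 nM.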

Compound 3, half-maximal inhibitory concentration: > 25000 nM
Compound 3 gave a limit, no number; the forecaster's own chance of this, stated with the estimate: 45%; middle value at least 1.2-fold (0.09 log units) from the limit.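

Compound 2 and compound 3 both stand only at a limit in this assay, so replacing amino with phenyl on this aromatic nitrogen gives no readable gain in strength: the limit of > 25000 nM in this assay, at which 2 of the 3 values shown sit. The step between these two limits cannot be read. The pair that differs in the group on the saturated chain carbon bound to a sulfur shows an at least 1.1-fold higher number from compound 1 to compound 3 (0.05 log units; that floor lies within the scatter).

Going by these compounds, it remains open how compound 2 and compound 3 actually differ in this assay. On these data alone, it also remains open whether methyl or a longer chain on this nitrogen would give a readable number.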